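A Phenyl Ring Replaces Fluorine: Lipophilicity Expected to Rise

The source may report more compounds than this note shows. Statements on the series, on what has been measured and on what is new or still open speak of the compounds shown alone.

Measured compounds:
compound 1 `O=C(O)CC(CC(=O)NNC(=O)CCCCNc1ccccn1)c1ccccc1`: 2.07
compound 2 `O=C(O)CC(CC(=O)NNC(=O)CCCCNc1ccccn1)c1ccc(F)cc1`: 2.23
compound 3 `O=C(O)CC(CC(=O)NNC(=O)CCCCNc1ccccn1)c1cc(Cl)cc(Cl)c1`: 3.19

In a physicochemical assay for lipophilicity (a higher number here means a more lipophilic compound, a lower number a more polar compound), compound 2 stands second highest of the three. The step of a number 0.16 log units higher from compound 1 to compound 2 (within the scatter) is small, while the step of a number 0.96 log units higher from compound 2 to compound 3 (beyond the scatter) is clearly larger, as is the step of a number 1.12 log units higher from compound 1 to compound 3 (beyond the scatter).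

Compound 4 `O=C(O)CC(CC(=O)NNC(=O)CCCCNc1ccccn1)c1ccc(-c2ccccc2)cc1` differs from compound 2 in one place: phenyl in place of fluoro on an aromatic carbon. The two steps leading to compound 3 show that adding substance to the aromatic ring on the saturated chain carbon moved this assay upward by a modest to large amount; the change here adds more than those did. An upward step beyond the scatter is therefore expected, estimated as a number 1.67 log units higher from compound 2 to compound 4 (beyond the scatter). Compound 4 is expected to give 3.9, with a range from 3.4 to 4.4.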

Compound 4, partition coefficient: 3.74
The estimate for compound 4 lay 0.16 log units above the measured number; low and high end bracket the measured number.
By their numbers in this assay, from the lowest: compounds 1 and 2 (each within the scatter of the next); then compound 3; then compound 4.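

At this aromatic carbon, para to a large group, this assay responds strongly to what enters: fluoro in place of hydrogen had stayed within the scatter, whereas phenyl in place of fluoro gives a number 1.51 log units higher from compound 2 to compound 4 (beyond the scatter) and phenyl in place of hydrogen gives a number 1.67 log units higher from compound 1 to compound 4 (beyond the scatter) at the same carbon. For the compounds shown here, compound 4 thus provides the first step beyond the scatter at this position. Nothing available here accounts for the size of these steps.

As far as these compounds go, whether an amine or a methoxy group at this carbon would lower the number remains open, as does whether a cyclohexyl ring would match phenyl.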